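Furan-to-thiophene ester swap on a diterpenoid lactone core

The compounds below may be only part of what the source reports. "The series", "measured", "known", "first", "only" and "open" are said of these compounds alone.

Measured in an ADME assay on HepG2 2.2.15 cells (Homo sapiens) for cytotoxicity, read by MTT assay; on this read-out higher numbers stand for lower toxicity in this test and lower numbers for higher toxicity in this test:
compound 1 `C=C1CC[C@@H]2[C@](C)(COC(=O)c3ccco3)[C@H](O)CC[C@@]2(C)[C@@H]1/C=C/C1=CCOC1=O`: 92000 nM
compound 2 `C=C1CC[C@@H]2[C@](C)(COC(=O)c3cccs3)[C@H](O)CC[C@@]2(C)[C@@H]1/C=C/C1=CCOC1=O`: 557000 nM
compound 3 `C=C1CC[C@@H]2[C@](C)(CO)[C@H](OC(=O)c3ccco3)CC[C@@]2(C)[C@@H]1C/C=C1\C=COC1=O`: 42000 nM

Compound 2 differs from compound 1 by thiophen-2-yl in place of furan-2-yl on a carbonyl carbon; this change gave a 6.1-fold higher number from compound 1 to compound 2 (0.78 log units; beyond the scatter). Among the measured compounds shown here, compound 3 gives the lowest of the three numbers in this assay; its values against compound 1 and compound 2 are beyond the scatter, but no step is broken down for either pair. The difference between the core of compound 3 and the core of compound 1 is not broken down here.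

Compound 4 `C=C1CC[C@@H]2[C@](C)(CO)[C@H](OC(=O)c3cccs3)CC[C@@]2(C)[C@@H]1C/C=C1\C=COC1=O` is not yet measured in this assay. It differs from compound 3 by thiophen-2-yl in place of furan-2-yl on a carbonyl carbon, the same change, at the same place, as from compound 1 to compound 2. Because a 6.1-fold higher number from compound 1 to compound 2 (0.78 log units; beyond the scatter) was seen once for this change, a step in the same direction is expected for compound 4, a 4.0-fold higher number from compound 3 to compound 4 (0.61 log units; beyond the scatter), kept somewhat smaller since it rests on one pair only. Compound 4 is estimated at 170000 nM in this assay, within 60000 nM to 500000 nM.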

Compound 4, half-maximal cytotoxic concentration: 257000 nM
Compound 4: the middle estimate sits 1.5-fold (0.18 log units) below what was measured; the measured number falls inside the stated range.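

In this assay, thiophen-2-yl in place of furan-2-yl on a carbonyl carbon gives a 6.1-fold higher number from compound 3 to compound 4 (0.79 log units; beyond the scatter). The step carries over between the two cores in direction and in size: the same change on two cores in this assay, a 6.1-fold higher number (0.78 log units; beyond the scatter) from compound 1 to compound 2 and a 6.1-fold higher number (0.79 log units; beyond the scatter) from compound 3 to compound 4, 1.0-fold (0.00 log units) apart, within the scatter of two such steps. Among the compounds shown here, these two pairs show only that the change transfers between these two cores in this one test; they do not explain the step, and they do not show how it would behave on any other core or in any other read-out.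

Open, from the compounds shown here alone, is whether a phenyl ring or a longer alkyl chain on the same carbonyl carbon would shift the number in the same way. Also open, going by these compounds, is how either core would respond to an amine in place of the ester oxygen.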